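This account rests on a few compounds, and the source may have more. Where it says the series, first, only, none or still open, it means among the compounds named here.

Working notes on the series sharing the core of compound 2, read in an assay on CHO-K1 cells for displacement of a labelled ligand from adenosine receptor A1 (Homo sapiens), read by scintillation counting, with a stated time of 60 min; on this read-out higher numbers stand for weaker inhibition and lower numbers for stronger inhibition. Compound 2 `Nc1nc(N/N=C/c2ccc3ncccc3c2)nc2c1ncn2[C@@H]1O[C@H](CO)[C@@H](O)[C@H]1O` gives 9.8 nM, the lowest of the two numbers measured here. Compound 1 `CC(/C=N/Nc1nc(N)c2ncn([C@@H]3O[C@H](CO)[C@@H](O)[C@H]3O)c2n1)Cc1ccc(C(C)C)cc1` gives 9500 nM, a gap from compound 2 that lies well beyond the scatter. Compound 3 `Nc1nc(N/N=C/c2ccc(OCc3ccccc3)c(OCc3ccccc3)c2)nc2c1ncn2[C@@H]1O[C@H](CO)[C@@H](O)[C@H]1O` returns > 10000 nM, which is a limit of this assay and not a number. The unmeasured compound 4 `CCCOc1ccc(/C=N/Nc2nc(N)c3ncn([C@@H]4O[C@H](CO)[C@@H](O)[C@H]4O)c3n2)cc1` differs from compound 2 by 4-propoxyphenyl in place of quinolin-6-yl on a carbon with a double bond to nitrogen. Within the data shown here, no step between measured pairs is available; the expectation rests on the gap between compound 2 and compound 1 and on (the limit of > 10000 nM in this assay, at which 1 of the 3 values shown sits). Replacing the quinolin-6-yl with 4-propoxyphenyl is expected to move the number upward, beyond the scatter, by a 51-fold higher number from compound 2 to compound 4 (1.71 log units; beyond the scatter). Compound 4 is thus expected to give 500 nM, between 50 nM and 5000 nM.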

Compound 4, inhibition constant: > 10000 nM
Compound 4: no number, only a limit; the forecaster's own chance of this, stated with the estimate: 10%; at least 20-fold (1.30 log units) between middle value and limit.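

In this assay, among these compounds, 4-propoxyphenyl in place of quinolin-6-yl on a carbon with a double bond to nitrogen gives an at least 1000-fold higher number from compound 2 to compound 4 (3.00 log units; beyond the scatter), the first single-place step at this position. Both groups have the same counts of heavy atoms, donors and acceptors, so those counts do not track this change. Compound 4 gives > 10000 nM, which is a limit of the assay and not a number: the limit of > 10000 nM in this assay, at which 2 of the 4 values shown sit.

As far as these compounds go, whether the loss follows from losing the second ring, losing the ring nitrogen or gaining the propoxy chain stays open. A naphthalen-2-yl or an unsubstituted phenyl on this carbon would help separate these.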